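Cytotoxicity of Three Amides and an Untested Fourth

This account rests on a few compounds, and the source may have more. Where it says the series, first, only, none or still open, it means among the compounds named here.

The measured compounds:
Compound 1 `CNS(=O)(=O)c1cccc(NC(=O)c2cc(-c3cccs3)nc3c2cnn3C(C)C)c1` gives 25000 nM in an ADME assay on LLC-MK2 cells (Macaca mulatta) for cytotoxicity, read by spectrophotometry and crystal violet staining, with a stated time of 4 days; a lower number here means that less compound is tolerated, a higher number that more compound is tolerated.
Compound 2 `CC(C)n1ncc2c(C(=O)Nc3cccnc3)cc(-c3ccsc3)nc21` gives 37000 nM in this assay.
Compound 3 `CC(C)n1ncc2c(C(=O)Nc3ncccn3)cc(-c3ccsc3)nc21` gives 50000 nM in this assay.

Compound 1 has the lowest of the three numbers in this assay, but its gap to compound 2 and its gap to compound 3 both lie within the scatter, so the three compounds cannot be ranked against one another. Going by the values given here, the only step between compounds that differ in a single place is a 1.4-fold higher number from compound 2 to compound 3 (0.13 log units; within the scatter), which also lies within the scatter.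

Compound 4 `CC(C)n1ncc2c(C(=O)Nc3cccc(C(N)=O)c3)cc(-c3cccs3)nc21` has not yet been measured. It differs from compound 1 by carbamoyl in place of methylsulfamoyl on an aromatic carbon. Among the compounds with values here, no measured pair shows this exchange, so nothing in the data speaks to it directly. Within the data shown here, the one available step, a 1.4-fold higher number from compound 2 to compound 3 (0.13 log units; within the scatter), shows that a change on the amide-type nitrogen left the number within the scatter, and the three compounds together sit in a narrow band. On that basis no step beyond the scatter is expected for a 1.2-fold higher number from compound 1 to compound 4 (0.08 log units; within the scatter) in this assay. Compound 4 is therefore estimated at 30000 nM, with a range from 12000 nM to 75000 nM.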

Compound 4, half-maximal cytotoxic concentration: 25000 nM
Compound 4: the middle estimate sits 1.2-fold (0.08 log units) above what was measured; low and high end bracket the measured number.
By their numbers in this assay, from the lowest: compounds 1, 4, 2 and 3 (each within the scatter of the next).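

Replacing methylsulfamoyl with carbamoyl on an aromatic carbon of the six-membered aromatic ring of carbon only, meta to a large group, gives no change at the digits printed from compound 1 to compound 4 (within the scatter) in this assay. Going by these compounds alone, this is the first measured exchange at this place: the earlier single-place step concerned the group on the amide-type nitrogen, whereas this one removes the sulfur, goes from 5 heavy atoms to 3 and from 2 hydrogen-bond acceptors to 1, and keeps 1 hydrogen-bond donor, all without moving the number beyond the scatter. No measurement shown here gives a reason for this result.

This single pair leaves open how a carboxylic acid, an amine or a longer chain at the same place would read in this assay. It also leaves open whether any change at this place can carry the number beyond the scatter, since this exchange is the only one shown there.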